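Replacing the halogenated phenyl group: an estimate for compound 4

The source may report more compounds than this note shows. Statements on the series, on what has been measured and on what is new or still open speak of the compounds shown alone.

Three compounds have been measured in a functional assay on CHO cells with adenosine receptor A1 (Homo sapiens) as the target, read by cAMP accumulation and immunoassay, with a stated time of 6 min, tested at 10 uM; on this read-out higher numbers stand for a weaker effect at the one concentration tested and lower numbers for a stronger effect:

compound 1, `Nc1scc(CN2CCN(c3cccc(Cl)c3Cl)CC2)c1C(=O)c1ccc(Cl)cc1`: -77%
compound 2, `Nc1scc(CN2CCN(c3ccc(F)cc3Cl)CC2)c1C(=O)c1ccc(Cl)cc1`: -70%
compound 3, `Nc1scc(CN2CCN(c3ccc(Cl)cc3F)CC2)c1C(=O)c1ccc(Cl)cc1`: -81%

Compound 3 gives the lowest number of the three. Against compound 1 it stays within the scatter, as a number 4 percentage points lower from compound 1 to compound 3 (within the scatter) shows, while against compound 2 there is a modest difference, a number 11 percentage points lower from compound 2 to compound 3 (beyond the scatter). Between the other two, a number 7 percentage points higher from compound 1 to compound 2 (within the scatter) lies within the scatter. All three measured steps exchange one halogen-bearing phenyl group for another on the same ring nitrogen, and none of them is large.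

Compound 4, `COc1ccc(N2CCN(Cc3csc(N)c3C(=O)c3ccc(Cl)cc3)CC2)cc1`, differs from compound 3 in one place: 4-methoxyphenyl in place of 4-chloro-2-fluorophenyl on an amine nitrogen in a ring. For the measured compounds named here, no measured step covers such an exchange, in which a chlorine and a fluorine leave and a methoxy group enters, so the three small halogen steps give only indirect guidance. Given that guidance, compound 4 is expected to show a step of a number 16 percentage points higher from compound 3 to compound 4 (beyond the scatter) in this assay, towards a higher number and so a somewhat weaker effect, with considerable uncertainty. The estimate for compound 4 is -65%, with a range from -90% to -30%.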

Compound 4, a percentage reported as activity, at one concentration (the size of the read-out at that concentration, not a potency): -52%
For compound 4 the middle estimate is 13 percentage points below the measured one; the measured number falls inside the stated range.
By their numbers in this assay, from the lowest: compounds 3, 1 and 2 (each within the scatter of the next, the first and the last beyond it); then compound 4.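

In this assay, the 4-methoxyphenyl group gives a change beyond the scatter against each earlier compound: a number 29 percentage points higher from compound 3 to compound 4 (beyond the scatter), a number 18 percentage points higher from compound 2 to compound 4 (beyond the scatter) and a number 25 percentage points higher from compound 1 to compound 4 (beyond the scatter). For the compounds shown here, the exchanges among halogen-bearing phenyl groups had moved the number only a little, so this is the first sign that the group on this ring nitrogen can shift the read-out more clearly, and compound 4 has the highest number of the four, which means the weakest effect at the one concentration tested. Nothing available here gives a reason for this shift.

As far as these compounds go, the exchange removes a chlorine and a fluorine and adds a methoxy group in a single move, so it remains open how much of the step goes with losing the halogens and how much with gaining the methoxy group. A plain phenyl group with no substituent could help to separate the two, and a phenyl group carrying a hydroxyl or an amine in place of the methoxy group would show whether other groups give a similar result.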